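Changing the Aryl Group on the Core of Compound 1

The source may hold more compounds than are shown below. What is called first, only, known or untested is meant among the compounds shown, and "the series" means these compounds.

Measured compounds:
compound 1 `CC(C)(C)c1ccc(-n2nc(-c3ccc(C(F)(F)F)cc3O)nc2-c2ccccc2O)cc1`: 77.8%
compound 2 `Oc1cc(C(F)(F)F)ccc1-c1nc(-c2ccccc2O)n(-c2ccc(C(F)(F)F)cc2)n1`: 90.5%
compound 3 `Oc1cc(C(F)(F)F)ccc1-c1nc(-c2ccccc2O)n(-c2cccc(C(F)(F)F)c2)n1`: 92.2%

In a functional assay on PC-12 cells (Rattus norvegicus) for cytotoxicity, read by MTT assay, with stated times of 2 h and 24 h, tested at 5 uM (on this read-out higher numbers stand for a stronger effect at the one concentration tested and lower numbers for a weaker effect), compound 1 gives the lowest of the three numbers, with compound 2 and compound 3 both above it beyond the scatter. Compound 4 `Cc1ccc(-n2nc(-c3ccc(C(F)(F)F)cc3O)nc2-c2ccccc2O)c(C)c1` differs from compound 1 in one place: 2,4-dimethylphenyl in place of 4-(tert-butyl)phenyl on an aromatic nitrogen. Within the data shown here, two measured steps bear on this change, since both also replace the same group on compound 1: a number 12.7 percentage points higher from compound 1 to compound 2 (beyond the scatter) and a number 14.4 percentage points higher from compound 1 to compound 3 (beyond the scatter). Neither step brings in 2,4-dimethylphenyl, so the parallel is loose, but both point the same way. A modest rise is therefore expected, a number 6.2 percentage points higher from compound 1 to compound 4 (within the scatter). Compound 4 is estimated at 84%, within a range of 72% to 95%.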

Compound 4, a percentage reported as activity, at one concentration (the size of the read-out at that concentration, not a potency): 93.3%
For compound 4 the middle estimate is 9.3 percentage points below the measured one; the measured number falls inside the stated range.
By their numbers in this assay, from the lowest: compound 1; then compounds 2, 3 and 4 (each within the scatter of the next).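

In this assay, the 2,4-dimethylphenyl group on the aromatic nitrogen gives a number 15.5 percentage points higher from compound 1 to compound 4 (beyond the scatter), so the rise over the 4-(tert-butyl)phenyl group also appears with a replacement that carries methyl groups and no trifluoromethyl. Against the two trifluoromethyl-bearing aryl groups the readings are a number 1.1 percentage points higher from compound 3 to compound 4 (within the scatter) and a number 2.8 percentage points higher from compound 2 to compound 4 (within the scatter), so these three aryl groups cannot be told apart here. Nothing measured here accounts for this result.

The compounds shown leave open how an aryl group bearing an amine or a carboxylic acid would read at this position. They also leave open how an unsubstituted phenyl group would compare with 4-(tert-butyl)phenyl there.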